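This account rests on a few compounds, and the source may have more. Where it says the series, first, only, none or still open, it means among the compounds named here.

Measured compounds in an assay on RPMI-8866 cells for inhibition of integrin alpha-4/beta-1 (Homo sapiens); a lower number here means a stronger inhibitor, a higher number a weaker inhibitor:
Compound 1 `C/C=C/[C@@H](CC(=O)O)NC(=O)[C@@H]1CCCN1S(=O)(=O)c1cc(Cl)cc(Cl)c1` gives 13 nM.
Compound 2 `O=C(O)C[C@@H](NC(=O)[C@@H]1CCN1S(=O)(=O)c1cc(Cl)cc(Cl)c1)c1ccc(OC2CC2)cc1` gives 0.31 nM.
Compound 3 `O=C(O)C[C@@H](NC(=O)[C@@H]1CCCN1S(=O)(=O)c1cc(Cl)cc(Cl)c1)c1ccc(OC2CC2)cc1` gives 0.85 nM.

Compound 2 stands lowest of the three numbers in this assay; compound 3 sits nearest, compound 1 furthest, both gaps beyond the scatter. Among the compounds with values here, the only single-point step among the measured compounds is a 15-fold lower number from compound 1 to compound 3 (1.18 log units; beyond the scatter), which concerns the group on the chain carbon, not the substituent on the aryl oxygen.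

Compound 4 `O=C(O)C[C@@H](NC(=O)[C@@H]1CCN1S(=O)(=O)c1cc(Cl)cc(Cl)c1)c1ccc(OCC(F)(F)F)cc1` differs from compound 2 by 2,2,2-trifluoroethyl in place of cyclopropyl on an oxygen on an aromatic ring. Within the data shown here, no measured step touches this oxygen substituent, so nothing among the measured compounds bears directly on it; the expectation is therefore a step of a 1.5-fold higher number from compound 2 to compound 4 (0.16 log units; within the scatter), within the scatter. For compound 4 the estimate in this assay is 0.45 nM, with a range from 0.15 nM to 1.4 nM.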

Compound 4, half-maximal inhibitory concentration: 1.4 nM
Compound 4: the middle estimate sits 3.1-fold (0.49 log units) below what was measured, within the range that was stated.
By their numbers in this assay, from the lowest: compound 2; then compounds 3 and 4 (each within the scatter of the next); then compound 1.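

In this assay the group on this oxygen is not silent: 2,2,2-trifluoroethyl in place of cyclopropyl gives a 4.5-fold higher number from compound 2 to compound 4 (0.65 log units; beyond the scatter) in this first reading at the position. The open-chain, fluorinated group is still accepted, with compound 4 at 1.4 nM on the core of compound 2. Nothing at hand accounts for the size of this step.

The compounds shown leave open whether the fluorine atoms or the loss of the ring carries the step, a question an ethyl group on the same oxygen would address. Going by these compounds, whether the step carries over to the core of compound 3 also remains open.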